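Swapping the amine on a trifluoromethyl compound

The source may hold more compounds than are shown below. What is called first, only, known or untested is meant among the compounds shown, and "the series" means these compounds.

In a functional assay on V79 cells (Cricetulus griseus) for cytotoxicity, read by colony formation (a higher number here means a weaker inhibitor, a lower number a stronger inhibitor), compound 1 (`CNCC1(C)CCN(c2c(F)cc3c(=O)c(C(=O)O)cn(C4CC4)c3c2F)C1`) gives 8 ug/mL and compound 2 (`CNCC1(C)CCN(c2c(F)cc3c(=O)c(C(=O)O)cn(C4CC4)c3c2C(F)(F)F)C1`) gives 230 ug/mL as the higher number of the two. Among the measured compounds shown here, the single measured step (a 29-fold higher number from compound 1 to compound 2 (1.46 log units; beyond the scatter)) puts trifluoromethyl in place of fluoro and changes nothing else. Compound 3 (`CC1CN(c2c(F)cc3c(=O)c(C(=O)O)cn(C4CC4)c3c2C(F)(F)F)CC(C)N1`) carries 3,5-dimethylpiperazin-1-yl in place of 3-methyl-3-((methylamino)methyl)pyrrolidin-1-yl (3,5-dimethylpiperazin-1-yl in place of 3-methyl-3-((methylamino)methyl)pyrrolidin-1-yl on an aromatic carbon) on an aromatic carbon. For the measured compounds named here, no measured step covers this swap, so in this assay no shift beyond the scatter is expected, and the expected move (a 1.3-fold lower number from compound 2 to compound 3 (0.11 log units; within the scatter)) stays small. Compound 3 is estimated at 180 ug/mL and a span from 60 ug/mL to 500 ug/mL is expected for it.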

Compound 3, half-maximal inhibitory concentration: > 500 ug/mL
Compound 3 gave a limit, no number; the forecaster's own chance of this, stated with the estimate: 15%; middle value at least 2.7-fold (0.44 log units) from the limit.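

With trifluoromethyl kept on the core, changing the amine on this aromatic carbon still moves the reading in this assay, with an at least 2.1-fold higher number from compound 2 to compound 3 (0.33 log units; beyond the scatter). Among the compounds shown here, the earlier swap of fluoro for trifluoromethyl is therefore not the only change here that gives a higher number. The reading for compound 3 is a limit, not a number: the limit of > 500 ug/mL in this assay, at which 1 of the 3 values shown sits.

Going by these compounds, how far compound 3 lies past that limit stays open. So does whether 3,5-dimethylpiperazin-1-yl would give a higher number with fluoro in place of trifluoromethyl, or how an unsubstituted piperazin-1-yl would read on the same carbon.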